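A few compounds are considered here, and "the series" means these few. Any claim that something is new, unique, unknown or untested is made for them only; others in the source may bear on it.

In a functional assay on BXPC-3 cells (Homo sapiens) for inhibition, read by XTT assay, with a stated time of 72 h (on this read-out higher numbers stand for weaker inhibition and lower numbers for stronger inhibition), the starting values are few. Compound 1 `CC(C)(C)OC(=O)N1CCC[C@H]1COCCCCCC/C=C/c1ccc(-c2ccccc2)cc1` reads > 100000 nM, which is a limit of the assay and not a number. Compound 2 `CC(C)(C)OC(=O)N1CCC[C@H]1COCCCCCC/C=C/c1ccc(Oc2ccccc2)cc1` gives 63300 nM and compound 3 `C=CCCCCCCOC[C@@H]1CCCN1[S+]([O-])c1ccc(C)cc1` gives 50000 nM, and these two values lie within the usual scatter of each other. Compound 2 therefore stands level with compound 3 on the numbers available.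

Compound 4 `CC(C)(C)OC(=O)NCC(=O)N1CCC[C@H]1COCCCCCC/C=C/c1ccc(Oc2ccccc2)cc1` differs from compound 2 by ((tert-butoxycarbonyl)amino)methyl in place of tert-butoxy on a carbonyl carbon. Among the measured compounds shown here, the only measured step is an at least 1.5-fold lower number from compound 1 to compound 2 (0.19 log units; that floor lies within the scatter). It places phenoxy in place of phenyl on an aromatic carbon, which is a different change at a different place, so it gives no size for the change at the carbonyl carbon. For the measured compounds named here, no measured step bears directly on this change, so the expectation starts from compound 2 at 63300 nM, with no shift in either direction beyond the scatter. The estimated 1.3-fold lower number from compound 2 to compound 4 (0.10 log units; within the scatter) is expected to stay within the scatter. Compound 1 stands at the limit of > 100000 nM in this assay, at which 1 of the 3 values shown sits, so compound 4 could also return only a limit. Compound 4 is expected at 50000 nM, with an estimated range from 15000 nM to 100000 nM.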

Compound 4, half-maximal inhibitory concentration: 80000 nM
Compound 4: the middle estimate sits 1.6-fold (0.20 log units) below what was measured; low and high end bracket the measured number.
By their numbers in this assay, from the lowest: compounds 3, 2 and 4 (each within the scatter of the next). At a limit, above all of these: compound 1.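

In this assay, among the compounds shown here, the change on the carbonyl carbon now has a measured size, which the earlier compounds could not give, since their only step concerned phenoxy and phenyl on an aromatic carbon: a 1.3-fold higher number from compound 2 to compound 4 (0.10 log units; within the scatter) for the exchange of tert-butoxy for ((tert-butoxycarbonyl)amino)methyl. The entering group is clearly larger and carries a hydrogen-bond donor that tert-butoxy lacks, yet the read-out does not separate compound 4 from compound 2, so this position accepts that exchange without a readable change in the number. For the compounds shown here, compound 1 remains the only compound at a limit, which is not a number: the limit of > 100000 nM in this assay, at which 1 of the 4 values shown sits.

Going by these compounds, both groups compared here end in tert-butoxycarbonyl, so it remains open whether a free amine in its place, a carboxylic acid or a small acetyl group on the same carbonyl carbon would move the number beyond the scatter. On these data alone, it is also open whether the same exchange would behave alike with phenyl in place of phenoxy on the aromatic carbon, or with a longer chain in the core.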